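Fluorinated sulfone series: metabolic stability notes, compound 4

The source may hold more compounds than are shown below. What is called first, only, known or untested is meant among the compounds shown, and "the series" means these compounds.

Measured so far in an ADME assay on microsomes from liver (Homo sapiens) for metabolic stability, tested at 2.5 uM; a lower number here means slower removal, a higher number faster removal of the compound:
compound 1 `COc1ccc(-c2c(S(=O)(=O)c3ccc(F)cc3)cnc3c(F)cccc23)cc1`, 2.41 mL/min
compound 2 `O=S(=O)(c1cccc(F)c1)c1cnc2c(F)cccc2c1-c1ccc(Cl)cc1`, 0.62 mL/min
compound 3 `O=S(=O)(c1cccc(F)c1)c1cnc2c(F)cccc2c1-c1cccc(Cl)c1`, 0.56 mL/min

Compound 2 stands second highest of the three numbers. For the measured compounds named here, its nearest neighbour is compound 3, and the one change that separates them, 3-chlorophenyl in place of 4-chlorophenyl on an aromatic carbon, gives a 1.1-fold lower number from compound 2 to compound 3 (0.04 log units; within the scatter), so the two values cannot be told apart. Going by the values given here, compound 1, which differs from compound 2 in more than one place, shows the only number in this set clearly apart from the others; no single-change step links it to compound 2, so its value only shows that the larger number is possible within the shared core.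

Compound 4 `O=S(=O)(c1cc(F)cc(F)c1)c1cnc2c(F)cccc2c1-c1ccc(Cl)cc1` is not yet measured. Against compound 2 it differs by fluoro in place of hydrogen on an aromatic carbon, which cut one bond further out reads 3-fluorophenyl to 3,5-difluorophenyl. Among the compounds with values here, no measured step bears on this change: the only step in hand concerns the chlorophenyl ring, not the sulfone aryl, and it lay within the scatter. With nothing in the data pointing either way, compound 4 is expected to sit close to compound 2, a step of no change at the digits printed from compound 2 to compound 4 (within the scatter) that would not go beyond the scatter. The estimate for compound 4 in this assay is therefore 0.62 mL/min, with a range from 0.3 mL/min to 1.3 mL/min.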

Compound 4, intrinsic clearance in a liver preparation (reported as CLH), per the amount of preparation that the assay uses: 0.73 mL/min
Compound 4: middle estimate off by 1.2-fold (0.07 log units), on the low side; the measured number falls inside the stated range.
By their numbers in this assay, from the lowest: compounds 3, 2 and 4 (each within the scatter of the next); then compound 1.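

In this assay, for the compounds shown here, the change from 3-fluorophenyl to 3,5-difluorophenyl gives the only reading so far on this ring, which the earlier single-change step on the chlorophenyl ring could not supply: a 1.2-fold higher number from compound 2 to compound 4 (0.07 log units; within the scatter). A second fluoro group on this ring, meta to the first, therefore leaves compound 4 indistinguishable from compound 2, and the two single-change steps now in hand, the other being a 1.1-fold lower number from compound 2 to compound 3 (0.04 log units; within the scatter), both lie within the scatter on two different rings. No measured evidence accounts for this result.

Going by these compounds alone, whether a trifluoromethyl group, an amine or a carboxylic acid on this ring would also leave the number within the scatter of compound 2 remains open, as fluoro is the only group read here. Within the data shown here, compound 1, at 2.41 mL/min, is still linked to the other compounds by no single-change step, so which of its differences goes with its number is also open.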